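A few compounds are considered here, and "the series" means these few. Any claim that something is new, unique, unknown or untested is made for them only; others in the source may bear on it.

Working notes on the series

The shared core is that of compound 1 `O/N=C(/Nc1ccccc1)c1ccc2occc2c1`, which in an assay on tissue (HeLa cells) for inhibition of Indoleamine 2,3-dioxygenase 1 (Homo sapiens), read by spectrophotometry (a lower number here means a stronger inhibitor, a higher number a weaker inhibitor), gives 19000 nM. Compound 2 `O=C(NCC1CCCCC1)c1cccc(N/C(=N/O)c2ccc3occc3c2)c1` adds a (cyclohexylmethyl)amino carbonyl on an aromatic carbon; in this assay compound 2 reaches only the assay limit, > 30000 nM. Compound 3 `CC1CCN(C(=O)c2cccc(N/C(=N/O)c3ccc4occc4c3)c2)CC1` carries a (4-methylpiperidin-1-yl)carbonyl at the same place; in this assay compound 3 likewise reaches only the assay limit, > 30000 nM. Compound 3 thus stands on a limit rather than a number, at the weak end of what has been measured, as the limit of > 30000 nM in this assay, at which 2 of the 3 values shown sit, records. Adding the (4-methylpiperidin-1-yl)carbonyl to the core gives an at least 1.5-fold higher number from compound 1 to compound 3 (0.19 log units; that floor lies within the scatter), and exchanging the amide substituent gives a step that the two limits leave unreadable from compound 2 to compound 3.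

Compound 4 `O/N=C(/Nc1cccc(-c2ccccc2)c1)c1ccc2occc2c1` is the unmeasured member; the change is phenyl in place of (4-methylpiperidin-1-yl)carbonyl on an aromatic carbon. Within the data shown here, no measured step places a phenyl here. Compound 1 shows that hydrogen at this place gives a readable number, while both carbonyl-bearing groups in compounds 2 and 3 reach the limit. Phenyl drops the carbonyl and the hydrogen-bond acceptor, so compound 4 is expected to return toward the readable range rather than remain on the limit. The step of an at least 2.5-fold lower number from compound 3 to compound 4 (0.39 log units; beyond the scatter) is therefore expected. Compound 4 is estimated at 12000 nM, with a range from 3000 nM to 30000 nM.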

Compound 4, half-maximal inhibitory concentration: 11900 nM
Beside the measured number, compound 4's estimate is 1.0-fold (0.00 log units) above it; low and high end bracket the measured number.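

Phenyl in place of (4-methylpiperidin-1-yl)carbonyl gives an at least 2.5-fold lower number from compound 3 to compound 4 (0.40 log units; beyond the scatter), so in this assay a large group at this position does not by itself send the value to the limit, and compound 4 shows that a ring at this place can carry a readable number. Set against hydrogen at the same carbon, phenyl gives a 1.6-fold lower number from compound 1 to compound 4 (0.20 log units; within the scatter), which places compound 1 and compound 4 within the scatter of each other and shows that this position takes a phenyl without a step that can be told from repeat measurement. Compound 3 remains a limit and not a number, so the step from it gives only a floor: the limit of > 30000 nM in this assay, at which 2 of the 4 values shown sit.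

Among these compounds, still open is whether the carbonyl or the amine part attached to it separates compound 3 from compound 4, as the two differ in both at once and no compound here carries one without the other. Also open, on these data alone, is how a methyl, a carboxylic acid or an aminomethyl group would read at this position, and whether a substituted phenyl would keep the number readable.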